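Methoxy Additions to the Aryl Ring: Working Notes

This account rests on a few compounds, and the source may have more. Where it says the series, first, only, none or still open, it means among the compounds named here.

Compound 1 `CC1=C(/C=C/C(=O)/C=C/c2ccccc2)C(C)(C)CCC1` is the unsubstituted parent of the set. In a functional assay on PC-3 cells (Homo sapiens) for cytotoxicity, read by sulforhodamine B assay, with a stated time of 48 h (a lower number here means a stronger inhibitor, a higher number a weaker inhibitor), compound 1 gives 12400 nM. Compound 2 `COc1ccccc1/C=C/C(=O)/C=C/C1=C(C)CCCC1(C)C` differs from it by methoxy in place of hydrogen on an aromatic carbon. In this assay compound 2 gives 14200 nM, a step of a 1.1-fold higher number from compound 1 to compound 2 (0.06 log units; within the scatter). Compound 3 `COc1ccc(/C=C/C(=O)/C=C/C2=C(C)CCCC2(C)C)cc1OC` gives 30200 nM in this assay; how its core differs from that of compound 1 is not broken down here, and the two values of compounds 2 and 3 show compound 3 with the higher number, beyond the scatter.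

Compound 4 `COc1cc(/C=C/C(=O)/C=C/C2=C(C)CCCC2(C)C)cc(OC)c1OC` is not yet measured. It differs from compound 3 by methoxy in place of hydrogen on an aromatic carbon. This is the same kind of change as from compound 1 to compound 2, not the same one: there the new group sat ortho to a large group, here it sits ortho to a methoxy group, meta to a large group and meta to a methoxy group.

The step of a 1.1-fold higher number from compound 1 to compound 2 (0.06 log units; within the scatter) is flat. The two values of compounds 2 and 3 in this assay show an upward move. A modest further rise is expected, an estimated step of a 1.3-fold higher number from compound 3 to compound 4 (0.10 log units; within the scatter). Compound 4 is estimated at 38000 nM, between 17000 nM and 85000 nM.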

Compound 4, half-maximal inhibitory concentration: 32600 nM
Compound 4: the middle estimate sits 1.2-fold (0.07 log units) above what was measured, within the range that was stated.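

In this assay, the new methoxy gives a small step (a 1.1-fold higher number from compound 3 to compound 4 (0.03 log units; within the scatter)), and the comparison with the earlier step shows no difference between the two cores: the same change on two cores in this assay, a 1.1-fold higher number (0.06 log units; within the scatter) from compound 1 to compound 2 and a 1.1-fold higher number (0.03 log units; within the scatter) from compound 3 to compound 4, 1.1-fold (0.03 log units) apart, within the scatter of two such steps. Within these two pairs, methoxy in place of hydrogen on an aromatic carbon therefore carries from one core to the other as a flat change, even though the group enters at a different place in each pair. This does not show that the change would stay flat at other ring positions, on other cores or in other assays, and two flat steps give no information on what underlies them.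

The compounds shown leave open whether a group other than methoxy on the aromatic ring, such as a hydroxy group, an amine or a carboxylic acid, would also leave the number flat. They also leave open whether a longer alkoxy chain in place of methoxy would give a step beyond the scatter.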